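Replacing one side group on a shared core

This account rests on a few compounds, and the source may have more. Where it says the series, first, only, none or still open, it means among the compounds named here.

Compound 1 `CCOC(=O)C1=C(N/N=C(\c2ccc([N+](=O)[O-])cc2)N2CCN(c3ccc(F)cc3)CC2)Nc2[nH]nc(C)c2C1c1ccc(N(C)C)cc1` and compound 2 `CCOC(=O)C1=C(N/N=C(\C#N)C(N)=O)Nc2[nH]nc(C)c2C1c1ccc(N(C)C)cc1` share a core and were both tested in a functional assay on HepG2 cells (Homo sapiens) for inhibition, read by MTT assay, with a stated time of 48 h (a higher number here means a weaker inhibitor, a lower number a stronger inhibitor), with a half-maximal inhibitory concentration as the read-out. Compound 1 gives 90200 nM and compound 2 gives 48400 nM in this test, and these two values lie within the scatter of each other. Compound 3 `CCOC(=O)C1=C(N/N=C(/Br)c2ccccc2)Nc2[nH]nc(C)c2C1c1ccc(N(C)C)cc1` has not yet been measured and departs from compound 2 by a single change (a group of 9 heavy atoms (7 carbon, 1 nitrogen, 1 bromine; one six-membered aromatic ring of carbon only) in place of a group of 7 heavy atoms (3 carbon, 3 nitrogen, 1 oxygen; no ring), on an amine nitrogen) in its side group. The entering group holds one six-membered aromatic ring of carbon only. For the measured compounds named here, no measured step bears directly on this change, so the two values alone guide the expectation. The expected change (a 1.1-fold higher number from compound 2 to compound 3 (0.06 log units; within the scatter)) stays within the scatter and has no firm direction. Compound 3 is estimated at 55000 nM in this test. The expected range for compound 3 runs from 18000 nM to 120000 nM once it is measured.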

Compound 3, half-maximal inhibitory concentration: 72000 nM
Compound 3: the middle estimate sits 1.3-fold (0.12 log units) below what was measured; the range from low to high includes it.
By their numbers in this assay, from the lowest: compounds 2, 3 and 1 (each within the scatter of the next).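

For the compounds shown here, the step at the amine nitrogen, a 1.5-fold higher number from compound 2 to compound 3 (0.17 log units; within the scatter), is the first reading of a single change at this position in this assay. It shows that a group with no ring, 1 hydrogen-bond donor and 3 hydrogen-bond acceptors can give way to one holding a six-membered aromatic ring of carbon only, with 0 hydrogen-bond donors and 1 hydrogen-bond acceptor, and the number stays within the scatter. No measurement is available that would account for this result.

The bromine and the aromatic ring entered together, so the compounds shown do not separate what each contributes. On these data alone, whether a carboxylic acid, a primary amine or a longer alkyl chain at this position would move the number beyond the scatter remains open.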